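The compounds below may be only part of what the source reports. "The series", "measured", "known", "first", "only" and "open" are said of these compounds alone.

Measured in an assay on isolated protein for inhibition of serine/threonine-protein kinase PAK 4 (Homo sapiens), read by HTRF, with a stated time of 60 min; a higher number here means a weaker inhibitor, a lower number a stronger inhibitor:
compound 1 `Cc1cc(Nc2nc(NCc3ccccc3)nc3[nH]ncc23)n[nH]1`: 1960 nM
compound 2 `Cc1cc(Nc2nc(NCc3ccccc3Cl)nc3[nH]ncc23)n[nH]1`: 668 nM
compound 3 `Cc1cc(Nc2nc(NCc3ccccc3Br)nc3[nH]ncc23)n[nH]1`: 1090 nM

Compound 3 holds the second highest of the three numbers; it lies within the scatter of compound 2, a 1.6-fold higher number from compound 2 to compound 3 (0.21 log units; within the scatter), and of compound 1, a 1.8-fold lower number from compound 1 to compound 3 (0.25 log units; within the scatter). Compound 4 `Cc1cc(Nc2nc(NCc3cccc(Br)c3)nc3[nH]ncc23)n[nH]1` carries the bromine elsewhere on the benzyl ring: 3-bromophenyl in place of 2-bromophenyl on a saturated chain carbon bound to a nitrogen on an aromatic ring. Going by the values given here, no measured step moves a substituent around the ring. The steps at hand add a halogen to the parent, a 2.9-fold lower number from compound 1 to compound 2 (0.47 log units; beyond the scatter) and a 1.8-fold lower number from compound 1 to compound 3 (0.25 log units; within the scatter), or exchange one halogen for the other, a 1.6-fold higher number from compound 2 to compound 3 (0.21 log units; within the scatter); only the chloro addition leaves the scatter. None of them shows whether a 3-bromophenyl ring reads like a 2-bromophenyl ring. Among the compounds with values here, with no bearing step, no change beyond the scatter is expected, a 1.0-fold higher number from compound 3 to compound 4 (0.00 log units; within the scatter). Compound 4 is estimated at 1100 nM, within 450 nM to 2700 nM. The range is wide because compound 1 gives 1960 nM and a parent-like outcome cannot be excluded.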

Compound 4, half-maximal inhibitory concentration: 4340 nM
Beside the measured number, compound 4's estimate is 3.9-fold (0.60 log units) below it; the measured number lies above the stated range.
By their numbers in this assay, from the lowest: compounds 2, 3 and 1 (each within the scatter of the next, the first and the last beyond it); then compound 4.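

Where the bromine stands on the benzyl ring matters: 3-bromophenyl in place of 2-bromophenyl gives a 4.0-fold higher number from compound 3 to compound 4 (0.60 log units; beyond the scatter), the first step here that turns on halogen placement rather than halogen identity. Against 2-chlorophenyl the same ring gives a 6.5-fold higher number from compound 2 to compound 4 (0.81 log units; beyond the scatter), and bromo added to the parent in this placement gives a 2.2-fold higher number from compound 1 to compound 4 (0.35 log units; beyond the scatter), making 3-bromophenyl the only halogen ring shown that reads weaker than the parent beyond the scatter. Nothing on hand gives a cause for these steps.

Still open, on these data alone, is how a methoxy group or an amine on the benzyl ring would read. Also open, as far as these compounds go, is whether a longer chain in place of the benzyl group would hold the number of compound 2.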